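Working notes: (4-chlorophenyl)amino in place of 2-methoxyphenyl

A few compounds are considered here, and "the series" means these few. Any claim that something is new, unique, unknown or untested is made for them only; others in the source may bear on it.

Measured so far in a functional assay on Jurkat cells (Homo sapiens) for antiproliferative activity, read by MTT assay, with a stated time of 72 h; a lower number here means a stronger inhibitor, a higher number a weaker inhibitor:
compound 1 `COc1cc(C(=O)c2sc3ccccc3c2-c2ccccc2)cc(OC)c1OC`: 1500 nM
compound 2 `COc1cc(C(=O)c2sc3ccccc3c2-c2ccc(C)cc2)cc(OC)c1OC`: 3300 nM
compound 3 `COc1ccccc1-c1c(C(=O)c2cc(OC)c(OC)c(OC)c2)sc2ccccc12`: 2900 nM

Compound 3 (2900 nM) lies within the scatter of both other compounds (a 1.9-fold higher number from compound 1 to compound 3 (0.29 log units; within the scatter); a 1.1-fold lower number from compound 2 to compound 3 (0.06 log units; within the scatter)). Only the first and second compounds are separated by more than the scatter, and only modestly (a 2.2-fold higher number from compound 1 to compound 2 (0.34 log units; beyond the scatter)).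

The next compound is compound 4 `COc1cc(C(=O)c2sc3ccccc3c2Nc2ccc(Cl)cc2)cc(OC)c1OC`, still to be measured. It carries (4-chlorophenyl)amino in place of 2-methoxyphenyl on an aromatic carbon of the five-membered aromatic ring with 1 sulfur ((4-chlorophenyl)amino in place of 2-methoxyphenyl on an aromatic carbon).

All three measured steps bear on this place, since each changes the aromatic group there. All three are small, and the swap of 4-methylphenyl for 2-methoxyphenyl is the closest in kind (a 1.1-fold lower number from compound 2 to compound 3 (0.06 log units; within the scatter)). Among the compounds with values here, none of the measured compounds has an amino group at this place, so the data do not show what that change does, and the range has to stay wide.

The step expected in this assay is none beyond the scatter (a 1.2-fold lower number from compound 3 to compound 4 (0.06 log units; within the scatter)). The estimated value for compound 4 is 2500 nM (expected range 500 nM to 10000 nM).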

Compound 4, half-maximal inhibitory concentration: 1900 nM
Estimate against measurement, compound 4: 1.3-fold (0.12 log units) above, and the stated range covers the measured number.
By their numbers in this assay, from the lowest: compounds 1, 4, 3 and 2 (each within the scatter of the next, the first and the last beyond it).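

In this assay, within the data shown here, the first amino-linked group at this place, the (4-chlorophenyl)amino of compound 4, brings a hydrogen-bond donor that the directly attached aromatic groups lack, yet all three steps to it stay within the scatter (a 1.5-fold lower number from compound 3 to compound 4 (0.18 log units; within the scatter); a 1.7-fold lower number from compound 2 to compound 4 (0.24 log units; within the scatter); a 1.3-fold higher number from compound 1 to compound 4 (0.10 log units; within the scatter)). Among these compounds, the series therefore keeps activity in the same range when an amino link stands between the aromatic carbon and the outer six-membered ring, and compound 4 sits within the scatter of both compound 1 and compound 2, the only pair separated by more than the scatter. No measurement shown here explains this outcome.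

Compound 4 differs from compound 1 in both the amino link and the chlorine, so the shown data cannot assign any share of the step to either, and the unsubstituted phenylamino group would be needed to separate them. As far as these compounds go, whether this place keeps the same range with a methylated amino nitrogen, a benzylamino group or a carboxylic acid also remains open.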